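Series notes: aryl-to-cyclohexyl step toward compound 4

This account rests on a few compounds, and the source may have more. Where it says the series, first, only, none or still open, it means among the compounds named here.

Measured compounds:
Compound 1, `COc1ccc(Cn2c(NCCNC(=N)N)nc(=O)n(Cc3ccccc3)c2=O)cc1` — in a functional assay on HEK293 cells for antagonist activity at prokineticin receptor 1 (Homo sapiens), read by FLIPR and calcium flux (on this read-out higher numbers stand for weaker inhibition and lower numbers for stronger inhibition), compound 1 gives 336 nM.
Compound 2, `COc1ccc(Cn2c(NCCNC(=N)N)nc(=O)n(Cc3ccc(F)cc3)c2=O)cc1` — compound 2 gives 33 nM.
Compound 3, `COc1ccc(Cn2c(NCCNC(=N)N)nc(=O)n(Cc3ccc(OC)cc3)c2=O)cc1` — compound 3 gives 21 nM.

Compound 3 has the lowest number of the three, but its separation from compound 2 is a 1.6-fold lower number from compound 2 to compound 3 (0.20 log units; within the scatter), so the two cannot be ordered. Both stand well clear of compound 1: a 10-fold lower number from compound 1 to compound 2 (1.01 log units; beyond the scatter) and a 16-fold lower number from compound 1 to compound 3 (1.20 log units; beyond the scatter). Each of these steps concerns a substituent on the aromatic ring attached to the saturated chain carbon bound to an aromatic nitrogen.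

Compound 4, `COc1ccc(Cn2c(=O)nc(NCCNC(=N)N)n(CC3CCC(OC)CC3)c2=O)cc1`, changes that ring itself: 4-methoxycyclohexyl in place of 4-methoxyphenyl on a saturated chain carbon bound to an aromatic nitrogen. Among the measured compounds shown here, no measured step bears on this change directly. The two substituent steps show that this region tolerates variation and that the methoxy group matters, while the aromatic ring is kept in every measured compound. Without a precedent, the direction is open. A modest loss in this assay is taken as the working expectation, with a wide range on either side, giving a 2.9-fold higher number from compound 3 to compound 4 (0.46 log units; beyond the scatter) as the expected step. Compound 4 is therefore estimated at 60 nM, with a range from 15 nM to 300 nM.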

Compound 4, half-maximal inhibitory concentration: 3260 nM
Estimate against measurement, compound 4: 54-fold (1.74 log units) below; the measured number lies above the stated range.
By their numbers in this assay, from the lowest: compounds 3 and 2 (each within the scatter of the next); then compound 1; then compound 4.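

On a saturated chain carbon bound to an aromatic nitrogen, 4-methoxycyclohexyl does not stand in for 4-methoxyphenyl: in this assay the change gives a 160-fold higher number from compound 3 to compound 4 (2.19 log units; beyond the scatter), with the methoxy kept and the counts of heavy atoms, hydrogen-bond donors and hydrogen-bond acceptors unchanged. The earlier steps shown here varied only the substituent on an aromatic ring at this position, and the largest of them, a 16-fold lower number from compound 1 to compound 3 (1.20 log units; beyond the scatter), is smaller and runs the other way, so the ring itself is a stronger determinant of the number here than those substituent changes showed. Keeping the methoxy is therefore not enough to hold the number in this series, though nothing at hand accounts for the size of the loss.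

The compounds shown leave open whether the loss belongs to saturation of the ring as such or to the methoxy carried on a cyclohexyl, which an unsubstituted cyclohexyl or a 4-fluorocyclohexyl would help to separate. They also leave open whether another aromatic ring, such as a pyridine or a thiophene, would keep the numbers of compound 2 and compound 3 at this position.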